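The compounds below may be only part of what the source reports. "The series", "measured", "known", "first", "only" and "open" are said of these compounds alone.

Measured in a functional assay on HeLa cells (Homo sapiens) for antiproliferative activity, read by sulforhodamine B assay; a lower number here means a stronger inhibitor of growth, a higher number a weaker inhibitor of growth:
- Compound 1 `CCC[C@@H]1O[C@H](COCc2ccccc2)[C@@H](OCc2ccccc2)[C@H](OCc2ccccc2)[C@H]1O`: 18900 nM
- Compound 2 `OCC[C@@H]1O[C@H](COCc2ccccc2)[C@@H](OCc2ccccc2)[C@H](OCc2ccccc2)[C@H]1O`: 30200 nM

With only these two values available, compound 2 cannot be ranked against compound 1, since the two lie within the scatter of each other. Compound 3 `OCCC[C@@H]1O[C@H](COCc2ccccc2)[C@@H](OCc2ccccc2)[C@H](OCc2ccccc2)[C@H]1O` is not yet measured. It differs from compound 2 by hydroxymethyl in place of hydroxy on a saturated chain carbon, two bonds along the chain from a saturated ring carbon. Cut one bond further out, this reads 2-hydroxyethyl to 3-hydroxypropyl.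

Within the data shown here, one measured step bears on this change, because it also alters the same chain: a 1.6-fold higher number from compound 1 to compound 2 (0.20 log units; within the scatter). Among the measured compounds shown here, that step is small, and it is the only guide available, so no clear shift is expected in this assay. The expected step is a 1.2-fold lower number from compound 2 to compound 3 (0.08 log units; within the scatter), which is estimated to stay within the scatter. Compound 3 is estimated at 25000 nM, with an expected range of 11000 nM to 55000 nM.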

Compound 3, concentration for 50% growth inhibition: > 50000 nM
Compound 3: no number, only a limit (the forecaster's own chance of this, stated with the estimate: 10%); at least 2.0-fold (0.30 log units) between middle value and limit.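

In this assay, compound 3 gives > 50000 nM, which is a limit and not a number. Among these compounds, the result offers the first step at this position that lies beyond the scatter: hydroxy in place of hydrogen on a saturated chain carbon, three bonds along the chain from a saturated ring carbon, gives an at least 2.6-fold higher number from compound 1 to compound 3 (0.42 log units; beyond the scatter). Going from 2-hydroxyethyl to 3-hydroxypropyl gives an at least 1.6-fold higher number from compound 2 to compound 3 (0.21 log units; that floor lies within the scatter), so this floor alone does not separate the two compounds, and the full size of the step stays unknown: the limit of > 50000 nM in this assay, at which 1 of the 3 values shown sits.

From the compounds shown here alone, whether an amine or a carboxylic acid in place of this hydroxy would read differently remains open. Also open, going by these compounds, is how a plain butyl chain, or a longer chain carrying hydroxy, would compare on the same core.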